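Swapping a Hydrogen for a Methylpiperidinyl Ring

The source may hold more compounds than are shown below. What is called first, only, known or untested is meant among the compounds shown, and "the series" means these compounds.

Compound 2 `Cc1nc(C)n(CC(=O)N2CCN(c3sc(C(F)(F)F)nc3-c3nc4ccccc4[nH]3)C[C@H]2C)n1` carries the higher of the two numbers recorded so far; in a functional assay on Venous blood for antagonist activity at C-X-C chemokine receptor type 3 (Homo sapiens), read by flow cytometry, with a stated time of 30 min, in the presence of a further agent that is not named here (on this read-out lower numbers stand for stronger inhibition and higher numbers for weaker inhibition), compound 2 gives 237 nM. Compound 1 `Cc1nc(C)n(CC(=O)N2CCN(c3sc(C(F)(F)F)nc3-c3nc4ccc(C5CCOCC5)cc4[nH]3)C[C@H]2C)n1` gives 123 nM in this assay, and the step of a 1.9-fold higher number from compound 1 to compound 2 (0.28 log units; within the scatter) lies within the scatter. Compound 3 `Cc1nc(C)n(CC(=O)N2CCN(c3sc(C(F)(F)F)nc3-c3nc4ccc(C5CCN(C)CC5)cc4[nH]3)C[C@H]2C)n1` differs from compound 2 by 1-methylpiperidin-4-yl in place of hydrogen on an aromatic carbon. Among the compounds with values here, the only comparable step, a 1.9-fold higher number from compound 1 to compound 2 (0.28 log units; within the scatter), alters the same position and stays within the scatter. For compound 3 a shift of about a 1.7-fold lower number from compound 2 to compound 3 (0.23 log units; within the scatter) is therefore expected, not beyond the scatter. Compound 3 is estimated at 140 nM, with a range of 50 nM to 400 nM.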

Compound 3, half-maximal inhibitory concentration: 84.7 nM
Estimate against measurement, compound 3: 1.7-fold (0.22 log units) above, and the stated range covers the measured number.
By their numbers in this assay, from the lowest: compounds 3, 1 and 2 (each within the scatter of the next, the first and the last beyond it).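

Of the two rings tried on this aromatic carbon, only 1-methylpiperidin-4-yl moves the number beyond the scatter from hydrogen in this assay (a 2.8-fold lower number from compound 2 to compound 3 (0.45 log units; beyond the scatter)), a modest gain. Exchanging oxan-4-yl for 1-methylpiperidin-4-yl gives a step within the scatter (a 1.5-fold lower number from compound 1 to compound 3 (0.16 log units; within the scatter)), so these two rings cannot be told apart here. No measurement shown explains the gain.

As far as these compounds go, whether the gain needs a ring at all stays open. An open-chain amine such as dimethylaminomethyl, or a carboxylic acid, on the same carbon could test this.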